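The compounds below may be only part of what the source reports. "The series", "measured", "known", "first", "only" and "open" are said of these compounds alone.

Compound 1 `CCOC(=O)C1=C(NN=C(C(C)=O)C(C)=O)Nc2[nH]nc(C)c2C1c1ccc(N(C)C)cc1` and compound 2 `CCOC(=O)C1=C(N/C=N/c2nnc(S(N)(=O)=O)s2)Nc2[nH]nc(C)c2C1c1ccc(N(C)C)cc1` share one core and differ only in the group attached to an amine nitrogen. Among the measured compounds shown here, in a functional assay on HeLa cells (Homo sapiens) for inhibition, read by MTT assay, with a stated time of 48 h (a higher number here means a weaker inhibitor, a lower number a stronger inhibitor), compound 1 gives 17000 nM, the lowest of the two numbers known here, and in this assay compound 2 gives 26300 nM. The step of a 1.5-fold higher number from compound 1 to compound 2 (0.19 log units; within the scatter) lies within the scatter, so these two values cannot be told apart. Compound 3 `CCOC(=O)C1=C(N/C=N/c2ccccn2)Nc2[nH]nc(C)c2C1c1ccc(N(C)C)cc1` departs from compound 1 by a group of 8 heavy atoms (6 carbon, 2 nitrogen; one six-membered aromatic ring with 1 hetero atom) in place of a group of 8 heavy atoms (5 carbon, 1 nitrogen, 2 oxygen; no ring), on an amine nitrogen. For the measured compounds named here, the one measured step that bears on this change is a 1.5-fold higher number from compound 1 to compound 2 (0.19 log units; within the scatter), where another group of similar size on the same amine nitrogen left the number within the scatter. No step beyond the scatter is therefore expected, and the estimated step is a 1.1-fold higher number from compound 1 to compound 3 (0.02 log units; within the scatter). Compound 3 is thus expected to give about 18000 nM in this assay, with a range from 7000 nM to 45000 nM.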

Compound 3, half-maximal inhibitory concentration: 29200 nM
The estimate for compound 3 lay 1.6-fold (0.21 log units) below the measured number; the range from low to high includes it.
By their numbers in this assay, from the lowest: compounds 1, 2 and 3 (each within the scatter of the next).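

Pyridin-2-yl on the amine nitrogen gives a third group at this place, and in this assay it stands within the scatter of both earlier groups, with a 1.7-fold higher number from compound 1 to compound 3 (0.23 log units; within the scatter) and a 1.1-fold higher number from compound 2 to compound 3 (0.05 log units; within the scatter). Where the earlier compounds offered a single step, the three compounds now give two further comparisons, and an open chain, a five-membered aromatic ring and a six-membered aromatic ring on this nitrogen cannot be told apart by their numbers. Nothing given here accounts for this result.

The compounds shown leave open whether another group on this amine nitrogen, such as a plain phenyl ring, a carboxylic acid or a longer alkyl chain, would move the number beyond the scatter. They also leave open what a change elsewhere on the shared core would do to the number in this assay.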